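Replacing the dimethylaminophenyl group in a thioether enone

This account rests on a few compounds, and the source may have more. Where it says the series, first, only, none or still open, it means among the compounds named here.

Measured compounds:
compound 1 `O=C(/C(=C\c1ccc(O)c([N+](=O)[O-])c1)SCc1ccc(Br)cc1)c1c(F)c(F)c(F)c(F)c1F` — 10000 nM
compound 2 `O=C(O)c1ccc(C(=O)/C(=C\c2ccccc2F)SCc2ccc(Br)cc2)cc1` — 10000 nM
compound 3 `CN(C)c1ccc(/C=C(/SCc2ccc(Br)cc2)C(=O)c2ccc(C(=O)O)cc2)cc1` — 50000 nM

The three measured compounds share a core in which a benzoyl group and a 4-bromobenzyl thioether sit on a double-bonded chain, and each was tested in a functional assay on DU-145 cells (Homo sapiens) for inhibition, read by trypan blue exclusion, with a stated time of 96 h; on this read-out lower numbers stand for stronger inhibition of growth and higher numbers for weaker inhibition of growth. In this assay compound 3 gives 50000 nM, the highest number of the three, and both compound 1 and compound 2 give lower numbers, each by a margin beyond the scatter. Going by the values given here, the one step that can be read cleanly, a 5.0-fold higher number from compound 2 to compound 3 (0.70 log units; beyond the scatter), came with the 4-(dimethylamino)phenyl group taking the place of the 2-fluorophenyl group.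

Compound 4 `O=C(O)c1ccc(C(=O)/C(=C\c2ccc(O)c([N+](=O)[O-])c2)SCc2ccc(Br)cc2)cc1` is not yet measured. It differs from compound 3 in one place: 4-hydroxy-3-nitrophenyl in place of 4-(dimethylamino)phenyl on a double-bonded chain carbon bound to a double-bonded chain carbon. Among the compounds with values here, the same 4-hydroxy-3-nitrophenyl group is carried by compound 1, which in this assay gives 10000 nM, though its core carries a pentafluorophenyl ketone rather than the carboxyphenyl ketone of compound 3 and compound 4, so no single step speaks to it directly. Because the dimethylaminophenyl group gave the weaker number in a 5.0-fold higher number from compound 2 to compound 3 (0.70 log units; beyond the scatter), its removal is expected to lower the number, estimated as a 5.0-fold lower number from compound 3 to compound 4 (0.70 log units; beyond the scatter). Compound 4 is therefore estimated at 10000 nM, with a range from 4000 nM to 30000 nM.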

Compound 4, concentration for 50% growth inhibition: 50000 nM
For compound 4 the middle estimate is 5.0-fold (0.70 log units) below the measured one, outside the stated range (above it).
By their numbers in this assay, from the lowest: compounds 1 and 2 (each within the scatter of the next); then compounds 3 and 4 (each within the scatter of the next).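

In this assay, putting 4-hydroxy-3-nitrophenyl in place of 4-(dimethylamino)phenyl on a double-bonded chain carbon gave no change at the digits printed from compound 3 to compound 4 (within the scatter) and so, on the carboxyphenyl ketone, these two groups cannot be told apart, while 2-fluorophenyl alone stands apart from both, as a 5.0-fold higher number from compound 2 to compound 4 (0.70 log units; beyond the scatter) now shows alongside a 5.0-fold higher number from compound 2 to compound 3 (0.70 log units; beyond the scatter) for the earlier pair. The 4-hydroxy-3-nitrophenyl group also does not fix the number by itself: with that group held constant, 4-carboxyphenyl in place of 2,3,4,5,6-pentafluorophenyl on a carbonyl carbon gave a 5.0-fold higher number from compound 1 to compound 4 (0.70 log units; beyond the scatter) and thus the group on the ketone side also moves the result. Nothing available explains any of these steps.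

On these data alone, whether the lower number of compound 2 belongs to the fluorine itself or to the plain ring that carries it stays open, and an unsubstituted phenyl or a 2-chlorophenyl group at this place would separate the two. As far as these compounds go, it is also open whether the ketone step seen with 4-hydroxy-3-nitrophenyl would recur with 2-fluorophenyl or with 4-(dimethylamino)phenyl on the chain, or with a simple methyl ketone on the carbonyl carbon.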